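Valine-type amide on a chlorinated quinolinone core

A few compounds are considered here, and "the series" means these few. Any claim that something is new, unique, unknown or untested is made for them only; others in the source may bear on it.

Three amides sharing one core have been tested in an assay on isolated protein for inhibition of Rho-associated protein kinase 2 (Homo sapiens); a higher number here means a weaker inhibitor, a lower number a stronger inhibitor. Compound 1 `CC(C)C[C@@H](N)C(=O)Nc1cc2cc[nH]c(=O)c2cc1Cl` gives 19 nM. Compound 2 `N[C@@H](C(=O)Nc1cc2cc[nH]c(=O)c2cc1Cl)C1CCCCC1` gives 400 nM, and compound 3 `O=C(Nc1cc2cc[nH]c(=O)c2cc1Cl)[C@H]1CCCN1` gives 130 nM. Among these three numbers compound 3 stands second highest, with compound 2 above it and compound 1 well below it. The two steps that connect the measured compounds are a 21-fold higher number from compound 1 to compound 2 (1.32 log units; beyond the scatter) and a 6.8-fold higher number from compound 1 to compound 3 (0.84 log units; beyond the scatter).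

Compound 4 `CC(C)[C@H](N)C(=O)Nc1cc2cc[nH]c(=O)c2cc1Cl` is the next compound, and it differs from compound 3 in one place: 1-amino-2-methylpropyl in place of pyrrolidin-2-yl on a carbonyl carbon. This change returns to an open-chain amino group of the kind found in compound 1, which gave the lowest number, but the entering group is a shorter chain than the isobutyl of compound 1, and compound 2 shows that a different group on the same carbon can raise the number considerably. For compound 4 the expected step is therefore a 2.2-fold lower number from compound 3 to compound 4 (0.34 log units; beyond the scatter), which would place its number below that of compound 3 and above that of compound 1. The estimated value for compound 4 is 60 nM, within a range of 20 nM to 200 nM.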

Compound 4, half-maximal inhibitory concentration: 12 nM
Estimate against measurement, compound 4: 5.0-fold (0.70 log units) above; measured number outside the range, below it.
By their numbers in this assay, from the lowest: compounds 4 and 1 (each within the scatter of the next); then compound 3; then compound 2.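

Replacing pyrrolidin-2-yl with 1-amino-2-methylpropyl on the carbonyl carbon gives an 11-fold lower number from compound 3 to compound 4 (1.03 log units; beyond the scatter) in this assay, even though both groups have the same counts of heavy atoms, hydrogen-bond donors and hydrogen-bond acceptors, so those counts alone do not track this large step. The two open-chain groups, 1-amino-3-methylbutyl and 1-amino-2-methylpropyl, cannot be told apart in this assay, with a 1.6-fold lower number from compound 1 to compound 4 (0.20 log units; within the scatter) as the step between them. Nothing measured here gives a reason for the size of either step.

The compounds shown leave open what a hydroxyl group in place of the open-chain amine on this carbon would do. They also leave open how a smaller group such as 1-aminoethyl, or the mirror-image form of 1-amino-2-methylpropyl, would compare.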